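Adding a Second Chloro to Compound 2

A few compounds are considered here, and "the series" means these few. Any claim that something is new, unique, unknown or untested is made for them only; others in the source may bear on it.

Compound 1 `COc1cc(C(=O)c2sc(-c3cccs3)cc2N)cc(OC)c1OC`: 9.8 nM
Compound 2 `COc1cc(C(=O)c2sc(-c3ccc(Cl)cc3)cc2N)cc(OC)c1OC`: 93 nM
Compound 3 `COc1cc(C(=O)c2sc(-c3ccc(F)cc3)cc2N)cc(OC)c1OC`: 20 nM

The three measured compounds share one core and differ only in the ring hung from it. In a functional assay on L1210 cells (Mus musculus) for antiproliferative activity (a lower number here means a stronger inhibitor, a higher number a weaker inhibitor), compound 2 gives the highest number of the three and is the weakest inhibitor among them: a 4.7-fold lower number from compound 2 to compound 3 (0.67 log units; beyond the scatter), and a 9.5-fold higher number from compound 1 to compound 2 (0.98 log units; beyond the scatter). Compound 4 `COc1cc(C(=O)c2sc(-c3ccc(Cl)c(Cl)c3)cc2N)cc(OC)c1OC` keeps the core of compound 2; the change is chloro in place of hydrogen on an aromatic carbon. Going by the values given here, no measured step makes this same change: one swaps fluoro for chloro, the others replace the whole ring. With nothing directly comparable, compound 4 is expected to stay close to compound 2, and the step of a 1.1-fold higher number from compound 2 to compound 4 (0.03 log units; within the scatter) is expected to fall within the scatter. The estimate for compound 4 in this assay is 100 nM, with a range from 30 nM to 350 nM.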

Compound 4, half-maximal inhibitory concentration: 260 nM
Estimate against measurement, compound 4: 2.6-fold (0.41 log units) below; the measured number falls inside the stated range.
By their numbers in this assay, from the lowest: compound 1; then compound 3; then compound 2; then compound 4.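

In this assay, going by these compounds alone, a second chloro, ortho to the first, weakens compound 2 (a 2.8-fold higher number from compound 2 to compound 4 (0.45 log units; beyond the scatter)), and no earlier step showed what adding a group to this ring does. With the 3,4-dichlorophenyl ring, compound 4 is the weakest of the four, further from the 4-fluorophenyl compound (a 13-fold higher number from compound 3 to compound 4 (1.11 log units; beyond the scatter)) and furthest from the thiophen-2-yl compound (a 27-fold higher number from compound 1 to compound 4 (1.42 log units; beyond the scatter)). No measured evidence accounts for this result. As far as these compounds go, whether the loss is particular to chloro stays open. A methyl or an amine on the same carbon could settle that.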